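A few compounds are considered here, and "the series" means these few. Any claim that something is new, unique, unknown or untested is made for them only; others in the source may bear on it.

Compound 3, with the structure `COC(=O)CC/C=C\CC[C@H]1C(=O)C[C@@H](O)[C@@H]1/C=C/C[C@@](C)(O)/C=C/C1CCCC1`, is the highest of the three measured numbers in a functional assay on the whole organism (stomach) with Canis familiaris (Canis lupus familiaris) as the target (a higher number here means that more compound is needed for the effect, a lower number that less compound is needed), where it gives 0.0003 mg/kg. Compound 1, `COC(=O)CC/C=C\CC[C@H]1C(=O)C[C@@H](O)[C@@H]1/C=C/CC(C)(O)CCC1CCCC1`, gives 0.00009 mg/kg in this assay, and compound 2, `COC(=O)CC/C=C\CC[C@H]1C(=O)C[C@@H](O)[C@@H]1/C=C/CC(C)(O)CCC1CCC1`, gives 0.00009 mg/kg; the step of a 3.3-fold higher number from compound 1 to compound 3 (0.52 log units; beyond the scatter) and the step of a 3.3-fold higher number from compound 2 to compound 3 (0.52 log units; beyond the scatter) both lie beyond the scatter, while the step of no change at the digits printed from compound 1 to compound 2 (within the scatter) does not.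

Compound 4, with the structure `COC(=O)CC/C=C\CC[C@H]1C(=O)C[C@@H](O)[C@@H]1/C=C/C[C@@](C)(O)/C=C/C1CCC1`, differs from compound 3 in one place: cyclobutyl in place of cyclopentyl on a double-bonded chain carbon bound to a double-bonded chain carbon. The measured step that bears most directly on this change is the step of no change at the digits printed from compound 1 to compound 2 (within the scatter), which swaps the same two rings, there on a saturated chain carbon, three bonds along the chain from an oxygen on a saturated carbon, and leaves the number where it was. On that basis no step beyond the scatter is expected for compound 4, and the estimated step is no change at the digits printed from compound 3 to compound 4 (within the scatter). Compound 4 is therefore expected to give about 0.0003 mg/kg in this assay, with a range from 0.00015 mg/kg to 0.0006 mg/kg.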

Compound 4, dose for half-maximal effect: 0.00005 mg/kg
Estimate against measurement, compound 4: 6.0-fold (0.78 log units) above; the whole stated range lies above it.
By their numbers in this assay, from the lowest: compounds 4, 1 and 2 (each within the scatter of the next); then compound 3.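

Moved onto the double-bonded chain carbon, the swap of cyclopentyl for cyclobutyl is no longer silent: in this assay there is a 6.0-fold lower number from compound 3 to compound 4 (0.78 log units; beyond the scatter) beyond the scatter, whereas the same swap on the saturated chain gave no change at the digits printed from compound 1 to compound 2 (within the scatter) and stayed within it. The 3-cyclobutyl-1-hydroxy-1-methylprop-2-en-1-yl group also stays within the scatter of both saturated side chains, with a 1.8-fold lower number from compound 2 to compound 4 (0.26 log units; within the scatter) and a 1.8-fold lower number from compound 1 to compound 4 (0.26 log units; within the scatter), so among these compounds only compound 3, which pairs the double bond with cyclopentyl, stands apart. Nothing given here explains why the ring swap reads differently on the two chains.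

The compounds shown leave open how a cyclohexyl or phenyl group would read at this place in this assay. They also leave open whether an open butyl chain could stand in for the ring.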